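The compounds below may be only part of what the source reports. "The series", "measured", "known", "first", "only" and "open" are said of these compounds alone.

Compound 3 `COc1cccc(C(=O)NCCCNc2nc3cc(C)cc(C)c3cc2C#N)c1` is one of two members of this series that returned a number. In an in vitro assay on FRT cells with Cystic fibrosis transmembrane conductance regulator variant F508del (Homo sapiens) as the target, read by fluorescence, with a stated time of 24 h, at 37 degrees C, in the presence of a further agent that is not named here (on this read-out lower numbers stand for an effect already at smaller amounts and higher numbers for an effect only at larger amounts of compound), compound 3 gives 4600 nM, the higher of the two numbers, while compound 2 `COc1ccc(C(=O)NCCNc2nc3cc(C)cc(C)c3cc2C#N)c(OC)c1` gives 4200 nM; the two values lie within the scatter of each other, so neither can be called the more potent. Compound 1 `Cc1cc(C)c2cc(C#N)c(NCCNC(=O)c3ccccc3)nc2c1` is reported in this assay only as "not active" (no number reported), with no number attached.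

Compound 4 `Cc1cc(C)c2cc(C#N)c(NCCCNC(=O)c3ccccn3)nc2c1` differs from compound 3 in one place: pyridin-2-yl in place of 3-methoxyphenyl on a carbonyl carbon. Among the compounds with values here, no step between two measured compounds isolates this change, and the one compound that also lacks a methoxy group on its terminal ring, compound 1, returned no number in this assay. The expectation for compound 4 is therefore a step in this assay a 1.5-fold higher number from compound 3 to compound 4 (0.18 log units; within the scatter) towards a higher number, with a real chance that only a limit is reported. Compound 4 is estimated at 7000 nM, with a range from 2500 nM to 25000 nM.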

Compound 4, half-maximal effective concentration: "not active" (no number reported)
The entry for compound 4 holds no number, so the estimate cannot be set against anything.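

In this assay, within the data shown here, compound 4 gives "not active" (no number reported) and compound 3 gives 4600 nM, so no step between them can be read. Nothing shown here accounts for this result. The compounds shown leave open how pyridin-2-yl compares in size of effect with 3-methoxyphenyl on that carbonyl carbon.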